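Urea Aryl Swap in a Pyrazole Series: Dichlorophenyl to Trifluoromethylphenyl

This account rests on a few compounds, and the source may have more. Where it says the series, first, only, none or still open, it means among the compounds named here.

Measured so far:
compound 1, `COc1cc(Cl)cc(-c2nn(-c3cccc(NC(=O)Nc4cc(C(F)(F)F)cc(C(F)(F)F)c4)c3)cc2-c2ccncc2)c1`, 38%
compound 2, `COc1cc(Cl)cc(-c2nn(-c3cccc(NC(=O)Nc4ccc(Cl)c(Cl)c4)c3)cc2-c2ccncc2)c1`, 91%

In a functional assay on HCC 2998 cells (Homo sapiens) for inhibition, read by sulforhodamine B assay, with a stated time of 48 h, tested at 1 uM (a higher number here means a weaker effect of the compound at the concentration tested, a lower number a stronger effect), compound 2 gives the highest of the two numbers, so the weakest effect; compound 1 gives 38%, a gap beyond the usual scatter. Compound 3, `COc1cc(Cl)cc(-c2nn(-c3cccc(NC(=O)Nc4cccc(C(F)(F)F)c4)c3)cc2-c2ccncc2)c1`, has not been measured. It differs from compound 2 by 3-(trifluoromethyl)phenyl in place of 3,4-dichlorophenyl on an amide-type nitrogen. Within the data shown here, with no measured step of this kind to lean on, the expectation for compound 3 is a moderate move toward a stronger effect, a number 21 percentage points lower from compound 2 to compound 3 (beyond the scatter), because compound 1 shows 38% with a related group. Compound 3 is therefore estimated at 70%, expected between 45% and 95%.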

Compound 3, a percentage reported as activity, at one concentration (the size of the read-out at that concentration, not a potency): 98%
Compound 3: middle estimate off by 28 percentage points, on the low side, and the stated range ends below it.
By their numbers in this assay, from the lowest: compound 1; then compounds 2 and 3 (each within the scatter of the next).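

In this assay, 3-(trifluoromethyl)phenyl in place of 3,4-dichlorophenyl on the amide-type nitrogen gives a number 7 percentage points higher from compound 2 to compound 3 (within the scatter), so this assay does not separate these two groups. One trifluoromethyl group alone therefore does not bring the stronger effect: hydrogen in place of trifluoromethyl on an aromatic carbon gives a number 60 percentage points higher from compound 1 to compound 3 (beyond the scatter), and the difference between these two compounds rests on that single group. Nothing measured here explains this difference.

Still open, as far as these compounds go, is whether a nitrile or an amine in that same place would match compound 1 or stay with compound 3.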